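Amide to hydroxypyrrolidinylmethyl amine: outlook for compound 4

The compounds below may be only part of what the source reports. "The series", "measured", "known", "first", "only" and "open" are said of these compounds alone.

Where compound 1 stands. In an assay on isolated protein for inhibition of sphingosine kinase 1 (Homo sapiens), read by mobility shift assay (a higher number here means a weaker inhibitor, a lower number a stronger inhibitor), compound 1 `CCCCCCCCc1ccc(NC(=O)C(C)(N)CO)cc1` returns > 10000 nM; this is a limit of the measurement and not a number, and the limit of > 10000 nM in this assay, at which 1 of the 3 values shown sits, marks it as the one such case among the three values in hand. Compound 2 `CCCCCCCCc1ccc(NC(=O)C(N)C(C)(C)O)cc1` gives 2100 nM in this assay, and compound 3 `CCCCCCCCc1ccc(CNC(=O)[C@H]2NCC[C@@H]2O)cc1` gives 430 nM.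

Measured step. For the measured compounds named here, the single one-place step in hand runs from compound 1 to compound 2: an at least 4.7-fold lower number from compound 1 to compound 2 (0.67 log units; beyond the scatter). Its size is open-ended, since compound 1 sits at the limit.

Change to compound 4 `CCCCCCCCc1ccc(NC[C@H]2NCC[C@@H]2O)cc1`: (3-hydroxypyrrolidin-2-yl)methyl in place of (1-amino-1-(hydroxymethyl)ethyl)carbonyl on a nitrogen on an aromatic ring. The carbonyl of compound 1 is gone, and the ring substituent sits directly on the nitrogen on the aromatic ring. Going by the values given here, no direct step to compound 4 is in hand from compound 3, whose value 430 nM shows that a 3-hydroxypyrrolidine arm is compatible with measurable inhibition in this assay.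

Expectation. The step of an at least 4.7-fold lower number from compound 1 to compound 2 (0.67 log units; beyond the scatter) shows that reshaping the side arm alone already moves the number off the limit. For compound 4 a step down beyond the scatter is therefore expected, an at least 6.6-fold lower number from compound 1 to compound 4 (0.82 log units; beyond the scatter). Compound 4 is estimated at 1500 nM, with a range from 300 nM to 8000 nM.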

Compound 4, half-maximal inhibitory concentration: 740 nM
The estimate for compound 4 lay 2.0-fold (0.31 log units) above the measured number; measured number inside the range.
By their numbers in this assay, from the lowest: compounds 3 and 4 (each within the scatter of the next); then compound 2. At a limit, above all of these: compound 1.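

Replacing (1-amino-1-(hydroxymethyl)ethyl)carbonyl with (3-hydroxypyrrolidin-2-yl)methyl on a nitrogen on an aromatic ring gives, in this assay, an at least 13-fold lower number from compound 1 to compound 4 (1.13 log units; beyond the scatter). A carbonyl on this nitrogen is therefore not required for a measurable number in the series: compound 4 carries none in its arm and gives 740 nM, a point that compound 1 and compound 2 could not settle, since both keep that carbonyl. The step remains open-ended because compound 1 stands at a limit and has no number of its own: the limit of > 10000 nM in this assay, at which 1 of the 4 values shown sits.

This change removes the carbonyl and brings in the five-membered ring at the same time, so the compounds shown cannot divide the step between these two features; a 2-amino-3-hydroxypropyl group on the same nitrogen, an open-chain arm without a carbonyl, would help to separate them. Also open is how the number depends on the two defined stereocentres of the (3-hydroxypyrrolidin-2-yl)methyl group, as no other stereoisomer of this arm, such as the mirror-image form, appears among the compounds shown.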